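Moving the halogen on the benzyl group

The source may hold more compounds than are shown below. What is called first, only, known or untested is meant among the compounds shown, and "the series" means these compounds.

Three compounds share one core. Compound 1 `O=C(O)c1ccccc1-c1ccc(CCc2ncc(C3CCCCC3)[nH]2)cc1` carries a cyclohexyl group, and in an in vitro functional assay on cells for agonist activity at Bombesin receptor subtype-3 (Homo sapiens), read by luminescence and calcium flux (a lower number here means that less compound is needed, a higher number that more compound is needed for the effect), compound 1 gives 375 nM. Compound 2 `O=C(O)c1ccccc1-c1ccc(CCc2ncc(Cc3ccccc3F)[nH]2)cc1` carries a 2-fluorobenzyl group instead, and compound 2 gives 177 nM. Compound 3 `O=C(O)c1ccccc1-c1ccc(CCc2ncc(Cc3ccccc3Cl)[nH]2)cc1` carries a 2-chlorobenzyl group, and compound 3 gives 292 nM. The number for compound 3 sits between the other two, but both gaps are within the scatter: a 1.3-fold lower number from compound 1 to compound 3 (0.11 log units; within the scatter) and a 1.6-fold higher number from compound 2 to compound 3 (0.22 log units; within the scatter). The exchanges of cyclohexyl for a halobenzyl read a 2.1-fold lower number from compound 1 to compound 2 (0.33 log units; beyond the scatter) and a 1.3-fold lower number from compound 1 to compound 3 (0.11 log units; within the scatter).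

Compound 4 `O=C(O)c1ccccc1-c1ccc(CCc2ncc(Cc3cccc(F)c3)[nH]2)cc1` differs from compound 3 by 3-fluorophenyl in place of 2-chlorophenyl on a saturated chain carbon bound to an aromatic carbon. Going by the values given here, the one measured step touching the halogen, a 1.6-fold higher number from compound 2 to compound 3 (0.22 log units; within the scatter), is within the scatter, and no measured step addresses a 3-fluorobenzyl group at all. In this assay no step beyond the scatter is therefore expected, with at most a modest tilt toward a lower number because compound 2 gives 177 nM. Compound 4 is expected at 220 nM, within a range from 90 nM to 500 nM, which means an expected step of a 1.3-fold lower number from compound 3 to compound 4 (0.12 log units; within the scatter).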

Compound 4, half-maximal effective concentration: 159 nM
Compound 4: the middle estimate sits 1.4-fold (0.14 log units) above what was measured; low and high end bracket the measured number.
By their numbers in this assay, from the lowest: compounds 4, 2, 3 and 1 (each within the scatter of the next, the first and the last beyond it).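

In this assay, moving fluorine on the benzyl group gives a 1.1-fold lower number from compound 2 to compound 4 (0.05 log units; within the scatter), and the exchange for 2-chlorophenyl gives a 1.8-fold lower number from compound 3 to compound 4 (0.26 log units; within the scatter), so neither the position of fluorine in these two compounds nor this change of halogen and position can be read as an effect at this place. Against cyclohexyl, 3-fluorobenzyl gives a 2.4-fold lower number from compound 1 to compound 4 (0.37 log units; beyond the scatter), which matches the 2-fluorobenzyl exchange, a 2.1-fold lower number from compound 1 to compound 2 (0.33 log units; beyond the scatter), while compound 3 goes against any general halobenzyl gain with a 1.3-fold lower number from compound 1 to compound 3 (0.11 log units; within the scatter). No outside data bear on these results.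

From the compounds shown here alone, whether a 3-chlorobenzyl group would separate the halogen from its position remains open. Also open, going by these compounds, is how an unsubstituted benzyl group or a methoxybenzyl group would compare with the fluorobenzyl groups at this place.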